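Chloro to Fluoro: One Atom Changed on Compound 2

The source may report more compounds than this note shows. Statements on the series, on what has been measured and on what is new or still open speak of the compounds shown alone.

Of the compounds shown here, three have been measured in an assay on membranes from brain for displacement of a labelled ligand from Neuronal acetylcholine receptor; alpha4/beta2 (Rattus norvegicus); a higher number here means a weaker inhibitor, a lower number a stronger inhibitor. Compound 1 `Cc1ncccc1OC[C@@H]1CCCN1C` gives 22.9 nM, compound 2 `CN1CCC[C@H]1COc1cncc(Cl)c1` gives 0.6 nM, and compound 3 `CN1CCC[C@H]1COc1cc(Br)c[n+]([O-])c1` gives 34.8 nM. Compound 2 therefore has the lowest number of the three and is the strongest inhibitor here; its gaps to compound 1 and to compound 3 are both well beyond the usual scatter of repeated measurements, so its place is secure. The new compound 4 `CN1CCC[C@H]1COc1cncc(F)c1` differs from compound 2 in a single spot: fluoro in place of chloro on an aromatic carbon. One halogen is exchanged for another, and nothing else moves. Within the data shown here, no measured pair in this set differs in just this way, so there is no direct precedent to lean on. Because compound 2 already gives 0.6 nM, a rather low number, there is more room for the number to rise than to fall, and a modest rise is expected. The step from compound 2 to compound 4 in this assay is estimated at a 3.3-fold higher number from compound 2 to compound 4 (0.52 log units; beyond the scatter). On that basis compound 4 is expected to give about 2 nM in this assay, within a range of 0.6 nM to 7 nM.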

Compound 4, inhibition constant: 0.69 nM
For compound 4 the middle estimate is 2.9-fold (0.46 log units) above the measured one; the range from low to high includes it.
By their numbers in this assay, from the lowest: compounds 2 and 4 (each within the scatter of the next); then compounds 1 and 3 (each within the scatter of the next).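

In this assay the swap of chloro for fluoro on this aromatic carbon, two atoms from the ring nitrogen, gives a 1.2-fold higher number from compound 2 to compound 4 (0.06 log units; within the scatter) and so leaves the two compounds indistinguishable. Among these compounds, this is the first pair in the set that differs in one place only, and it gives the first direct reading of this position: here the two halogens cannot be told apart by this measurement, even though a change of one atom could in principle have moved the number well beyond the scatter. That is one pair and one exchange, so it sets no rule for other groups, and nothing available here explains why the two halogens read alike.

The compounds shown leave open whether this position accepts groups other than halogens, such as a nitrile, a methoxy group or an amine, and what happens with plain hydrogen on this carbon. They also leave open whether the same exchange of chloro for fluoro would give so small a step on a different core, such as that of compound 1.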